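Adamantane spiro series: acid to hydroxamic acid

The source may hold more compounds than are shown below. What is called first, only, known or untested is meant among the compounds shown, and "the series" means these compounds.

Measured compounds:
compound 1 `O=C(NC1CCC2(CC1)OCC1(CO2)C2CC3CC(C2)CC1C3)c1ccc(O)c(O)c1` — 30100 nM
compound 2 `Oc1ccc(NC2CCC3(CC2)OOC2(OO3)C3CC4CC(C3)CC2C4)c2cccnc12` — 6000 nM
compound 3 `O=C(O)[C@H]1CC[C@@]2(CC1)OC[C@]1(OO2)C2CC3CC(C2)CC1C3` — a limit only

In a functional assay on HL-60 cells (Homo sapiens) for cytotoxicity, read by MTT assay, with a stated time of 48 h (on this read-out lower numbers stand for stronger inhibition and higher numbers for weaker inhibition), compound 3 gives > 100000 nM, which is a limit of the assay and not a number. Compound 3 thus stands at the weak end of the values shown, on (the limit of > 100000 nM in this assay, at which 1 of the 3 values shown sits). Compound 4 `O=C(NO)[C@H]1CC[C@@]2(CC1)OC[C@]1(OO2)C2CC3CC(C2)CC1C3` is not yet measured; it differs from compound 3 by hydroxyamino in place of hydroxy on a carbonyl carbon. Going by the values given here, no measured pair covers this change, so its effect is unknown. In this assay a modest step toward stronger inhibition is expected, of a size near or slightly beyond the scatter, as an at least 2.0-fold lower number from compound 3 to compound 4 (0.30 log units; that floor lies within the scatter). Compound 4 is expected at 50000 nM, within 10000 nM to 150000 nM, with a fair chance that only a limit is reported again.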

Compound 4, half-maximal inhibitory concentration: > 50000 nM
Compound 4: only a limit was reported; the forecaster's own chance of this, stated with the estimate: 45%; the middle value sits exactly at the limit.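

In this assay compound 3 gives > 100000 nM, a limit of the assay. Compound 4 gives > 50000 nM, also a limit, so no step can be read against compound 3. From the compounds shown here alone, whether hydroxyamino in place of hydroxy on a carbonyl carbon changes inhibition stays open.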